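Bromo in Place of Ethoxy: Compound 4 Awaited

The source may report more compounds than this note shows. Statements on the series, on what has been measured and on what is new or still open speak of the compounds shown alone.

Compound 1 `CCOc1ccc2c(c1)NC(=O)Nc1cnc(C#N)c(n1)OCC/C=C\CO2` reached only a limit in a functional assay on NCI-H1299 cells (Homo sapiens), read by flow cytometry; a lower number here means that less compound is needed, a higher number that more compound is needed for the effect: > 10000 nM.
Compound 2 `N#Cc1ncc2nc1OCC/C=C\COc1ccc(Br)cc1NC(=O)N2` likewise gave only a limit in this assay: > 10000 nM.
Compound 3 `CCOc1ccc2c(c1)NC(=O)Nc1cnc(C#N)c(n1)OCCCCCO2` also stopped at a limit in this assay: > 10000 nM.

The change that matters here is bromo in place of ethoxy on an aromatic carbon. Its effect on this assay, the step that the two limits leave unreadable from compound 1 to compound 2, cannot be read because both compounds sit at the limit of > 10000 nM in this assay, at which 3 of the 3 values shown sit. Compound 3 carries the ethoxy group of compound 1 on a different core; the difference between the two cores is not broken down here. Compound 3 itself stands only at a limit, so it adds nothing beyond what compound 1 and compound 2 already show.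

Compound 4 `N#Cc1ncc2nc1OCCCCCOc1ccc(Br)cc1NC(=O)N2` is the not yet measured partner of compound 3. It differs from compound 3 by bromo in place of ethoxy on an aromatic carbon, which is the same change, in the same place, that turns compound 1 into compound 2. Within the data shown here, with every value so far at the limit and the single precedent for this change unreadable, the expectation for compound 4 rests on the pattern alone: since compound 3 gives > 10000 nM and the same change on compound 1 still left compound 2 at a limit, compound 4 is expected to remain at a limit as well. The step that the limit leaves unreadable from compound 3 to compound 4 is therefore estimated to be close to nothing, and compound 4 is estimated at 15000 nM, between 5000 nM and 50000 nM.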

Compound 4, half-maximal effective concentration: 10000 nM
The estimate for compound 4 lay 1.5-fold (0.18 log units) above the measured number; low and high end bracket the measured number.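

Carried onto the core of compound 3, bromo in place of ethoxy on an aromatic carbon leaves compound 4 with a measured number in this assay, 10000 nM, the only value shown that is not a limit. Compound 3 has only a limit, > 10000 nM. On this core the change gives a number no higher from compound 3 to compound 4 (the limit leaves the size open), but how large the step is, or whether there is any step at all, cannot be read, and the same holds for the matching step on the core of compound 1. The two pairs therefore agree only in that neither shows the change raising the number, and they do not show that the change lowers the number on either core or that its effect carries from one core to the other, with most of the series still at one limit: the limit of > 10000 nM in this assay, at which 3 of the 4 values shown sit.

The compounds shown leave open whether another group on this aromatic carbon, such as an amine or a carboxylic acid, would bring the number clearly under the level that compound 4 reaches. They also leave open whether a longer chain in place of ethoxy would do so, and whether any such gain would hold on both cores.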